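Trifluoromethyl in Place of 5-Fluoropyridin-2-yl: Expected Cell Tolerance

This account rests on a few compounds, and the source may have more. Where it says the series, first, only, none or still open, it means among the compounds named here.

Measured compounds:
compound 1, `CC1CN(C(=O)Nc2cc(F)c(F)c(F)c2)Cc2c(N3CC(C#N)CC3=O)cnn21`: 115000 nM
compound 2, `O=C1CC(c2ccc(F)cn2)CN1c1cnn2c1CN(C(=O)Nc1cc(F)c(F)c(F)c1)C(C1CC1)C2`: 38500 nM
compound 3, `C[C@H]1Cn2ncc(N3CC(c4ccccc4)CC3=O)c2CN1S(=O)(=O)Nc1cc(F)c(F)c(F)c1`: > 2000 nM

All three were tested in a toxicity assay on HepG2 2.2.15 cells (Homo sapiens) for cytotoxicity, read by CellTiter-Glo; a lower number here means that less compound is tolerated, a higher number that more compound is tolerated. Compound 3 gives only a limit of the assay, > 2000 nM, and not a number. Of the two real numbers, compound 2 stands lowest, and compound 1 sits above it by a gap beyond the usual scatter, so less of compound 2 is tolerated. Compound 4, `O=C1CC(C(F)(F)F)CN1c1cnn2c1CN(C(=O)Nc1cc(F)c(F)c(F)c1)C(C1CC1)C2`, has not yet been measured. It differs from compound 2 in one place: trifluoromethyl in place of 5-fluoropyridin-2-yl on a saturated ring carbon. Among the compounds with values here, no step between measured compounds is known here, so the direction can only be expected. The step of a 1.8-fold higher number from compound 2 to compound 4 (0.26 log units; within the scatter) is expected to be a modest rise in this assay. Compound 4 is estimated at 70000 nM, within 25000 nM to 160000 nM.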

Compound 4, half-maximal cytotoxic concentration: 115000 nM
Compound 4: the middle estimate sits 1.6-fold (0.22 log units) below what was measured; the range from low to high includes it.
By their numbers in this assay, from the lowest: compound 2; then compounds 1 and 4 (each within the scatter of the next).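

In this assay, within the data shown here, the change gives a 3.0-fold higher number from compound 2 to compound 4 (0.48 log units; beyond the scatter), the first step measured between compounds that differ only at this saturated ring carbon. It shows that swapping a six-membered aromatic ring for a trifluoromethyl group with no ring at this position moves the number upward, beyond the scatter. Nothing measured here accounts for this rise. On these data alone, one step cannot show a trend, so it stays open how an amine, a carboxylic acid or a longer chain would behave at this position.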